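The compounds below may be only part of what the source reports. "The series", "measured", "known", "first", "only" and "open" are said of these compounds alone.

Compound 3, `Cc1ccc(S(=O)(=O)N2C(C)C2CO[C@@H]2O[C@@H]3CO[C@H](c4ccccc4)O[C@@H]3[C@H](O)[C@H]2O)cc1`, is the diol of this small set, and in an ADME assay on MRC5 cells (Homo sapiens) for cytotoxicity, read by MTT assay, with a stated time of 48 h (a higher number here means a weaker inhibitor, a lower number a stronger inhibitor), compound 3 gives 544000 nM. That is the highest of the two numbers measured outright; the nearest is compound 1, `Cc1ccc(S(=O)(=O)N2CC2CO[C@@H]2O[C@@H]3CO[C@H](c4ccccc4)O[C@@H]3[C@H](OCc3ccccc3)[C@H]2OCc2ccccc2)cc1`, which in this assay gives 183000 nM, a gap that lies beyond the usual scatter. Among the compounds with values here, compound 2, `Cc1ccc(S(=O)(=O)N2C(CO[C@@H]3O[C@@H]4CO[C@H](c5ccccc5)O[C@@H]4[C@H](OCc4ccccc4)[C@H]3OCc3ccccc3)C2(C)C)cc1`, carries two methyl groups on its three-membered ring and keeps the three benzyl-type protecting groups; in this assay compound 2 returns only the limit > 1000000 nM, not a number. the limit of > 1000000 nM in this assay, at which 1 of the 3 values shown sits, is therefore the only information for a doubly methylated ring.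

Compound 4, `Cc1ccc(S(=O)(=O)N2C(CO[C@@H]3O[C@@H]4CO[C@H](c5ccccc5)O[C@@H]4[C@H](O)[C@H]3O)C2(C)C)cc1`, is the counterpart of compound 3 in which (methyl in place of hydrogen on a saturated ring carbon). Within the data shown here, no measured pair differs by exactly this change, so the size of the step can only be expected, not read. What compound 1 and compound 2 show is that the more heavily methylated ring went with a value at the limit, and compound 3 already sits high. A step toward a weaker inhibitor is expected for compound 4, of the order of a 1.7-fold higher number from compound 3 to compound 4 (0.22 log units; within the scatter), with a real chance that the assay again reports only a limit. Compound 4 is estimated at 900000 nM, within 400000 nM to 2000000 nM.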

Compound 4, half-maximal inhibitory concentration: 567000 nM
The estimate for compound 4 lay 1.6-fold (0.20 log units) above the measured number, within the range that was stated.
By their numbers in this assay, from the lowest: compound 1; then compounds 3 and 4 (each within the scatter of the next). At a limit, above all of these: compound 2.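

In this assay, within the data shown here, this pair gives the first direct reading of methyl in place of hydrogen on a saturated ring carbon of the three-membered ring, and a 1.0-fold higher number from compound 3 to compound 4 (0.02 log units; within the scatter) means that the two compounds cannot be told apart at this position. The earlier compounds shown here offered no such pair, so the change could not be sized until now. Among the diols, a ring with two methyl groups still gives a measured number, as compound 4 gives 567000 nM. Compound 2, which has two methyl groups on its ring and keeps its benzyl-type protecting groups, remains the only compound at a limit, which is not a number: the limit of > 1000000 nM in this assay, at which 1 of the 4 values shown sits.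

The compounds shown leave open whether the same step holds when the benzyl groups are in place, since the only pair read here carries the free diol. They also leave open how this assay would respond at this ring carbon to a longer chain such as ethyl, to an amine or to a carboxylic acid in place of the methyl.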